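Phenyl for bromo: what to expect for compound 3

The source may report more compounds than this note shows. Statements on the series, on what has been measured and on what is new or still open speak of the compounds shown alone.

Measured so far:
compound 1, `O=C(N1CC=C[C@@H](O)[C@@H]1COCc1ccccc1)n1cc(-c2ccc(-c3ccccc3)cc2)nn1`, in an assay on HEK293 cells for inhibition of diacylglycerol lipase-alpha (Homo sapiens), read by colorimetric assay, with stated times of 30 min, 60 s and 20 min; a higher number here means a weaker inhibitor, a lower number a stronger inhibitor: > 10000 nM
compound 2, `O=C(N1CCC=C[C@@H]1COCc1ccccc1)n1cnc(-c2ccc(Br)cc2)c1`, in this assay: > 10000 nM

The value of compound 1 is a limit of this assay, not a number. The value of compound 2 is likewise a limit, so compound 2 stands at the edge of what this assay reports, together with the other value shown (the limit of > 10000 nM in this assay, at which 2 of the 2 values shown sit). Compound 3 `O=C(N1CCC=C[C@@H]1COCc1ccccc1)n1cnc(-c2ccc(-c3ccccc3)cc2)c1` differs from compound 2 by phenyl in place of bromo on an aromatic carbon. No measured step covers this change, and nothing among the shown values points either way. The expected step that the limit leaves unreadable from compound 2 to compound 3 is therefore none beyond the scatter. Compound 3 is estimated at 15000 nM, between 3000 nM and 60000 nM, most probably again reported only as a limit.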

Compound 3, half-maximal inhibitory concentration: > 10000 nM
Compound 3: only a limit was reported (the forecaster's own chance of this, stated with the estimate: 75%); the middle value lies beyond the limit too.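

No step can be read from compound 2 to compound 3, since both are reported only as limits: the limit of > 10000 nM in this assay, at which 3 of the 3 values shown sit.

The compounds shown leave open how strongly any of them inhibits the enzyme, and which change would give a readable number.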